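Trimming the ketone chain of a chlorophenyl selenoester

The compounds below may be only part of what the source reports. "The series", "measured", "known", "first", "only" and "open" are said of these compounds alone.

Measured so far:
compound 1 `COc1cc(OC)cc(C(=O)[Se]CC(=O)C(C)(C)C)c1` gives 350 nM
compound 2 `CC(C)(C)C(=O)C[Se]C(=O)c1ccc(Cl)cc1` gives 960 nM
compound 3 `C[Se]C(=O)c1ccc(C(=O)[Se]C)cc1` gives only a limit, > 100000 nM

In a functional assay on COLO 320 cells (Homo sapiens) for cytotoxicity, read by MTT assay, with a stated time of 24 h (a higher number here means a weaker inhibitor, a lower number a stronger inhibitor), compound 2 stands at 960 nM, the higher of the two numbers reported; compound 1 gives 350 nM, and the gap between the two lies beyond the usual scatter. For compound 3 this assay reports only a limit, > 100000 nM, and no number. Compound 4 `CC(=O)C[Se]C(=O)c1ccc(Cl)cc1` has not yet been measured; it differs from compound 2 by methyl in place of tert-butyl on a carbonyl carbon. No step of this kind has been measured among these compounds, so its direction is open. Compound 4 is expected to give about 1500 nM in this assay, with a likely range from 400 nM to 6000 nM. The step of a 1.6-fold higher number from compound 2 to compound 4 (0.19 log units; within the scatter) is expected to be at most a small weakening, close to the scatter.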

Compound 4, half-maximal inhibitory concentration: 550 nM
For compound 4 the middle estimate is 2.7-fold (0.44 log units) above the measured one; measured number inside the range.
By their numbers in this assay, from the lowest: compounds 1, 4 and 2 (each within the scatter of the next, the first and the last beyond it). At a limit, above all of these: compound 3.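

Among the compounds shown here, until now no step at this position had been read. Methyl in place of tert-butyl on a carbonyl carbon gives a 1.7-fold lower number from compound 2 to compound 4 (0.24 log units; within the scatter) in this assay and so the two compounds cannot be told apart here: a value in this range does not depend on the tert-butyl. Nothing measured here bears on the cause of this step.

The compounds shown leave open whether an ethyl group or a longer chain on that carbonyl carbon would read the same. They also leave open what a phenyl ring or an amine there would give.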